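Phenylsulfonyl to benzoyl on the shared core of compound 3

The compounds below may be only part of what the source reports. "The series", "measured", "known", "first", "only" and "open" are said of these compounds alone.

Of the compounds shown here, three built on one core have been measured. Compound 1 `COc1ccc(-c2[nH]c3ccccc3c2/C=C(\C#N)S(=O)(=O)c2ccccc2)cc1` gives 932 nM in a functional assay on NCI-H23 cells (Homo sapiens) for inhibition, read by sulforhodamine B assay, with a stated time of 48 h; on this read-out lower numbers stand for stronger inhibition of growth and higher numbers for weaker inhibition of growth. Compound 2 `CC(=O)/C(=C\c1c(-c2ccccc2)[nH]c2ccccc12)S(=O)(=O)c1ccccc1` gives 1600 nM in this assay. Compound 3 `N#C/C(=C\c1c(-c2ccccc2)[nH]c2ccccc12)S(=O)(=O)c1ccccc1` gives 4700 nM in this assay, the highest number of the three, so that it is the weakest inhibitor of growth among them: a 5.0-fold higher number from compound 1 to compound 3 (0.70 log units; beyond the scatter), and a 2.9-fold higher number from compound 2 to compound 3 (0.47 log units; beyond the scatter).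

Compound 4 `N#C/C(=C\c1c(-c2ccccc2)[nH]c2ccccc12)C(=O)c1ccccc1` differs from compound 3 in one place: benzoyl in place of phenylsulfonyl on a double-bonded chain carbon bound to a double-bonded chain carbon and a triple-bonded carbon. Neither measured step touches this part of the molecule. The step from compound 1 to compound 3 removes a methoxy group on an aromatic carbon, and the step from compound 2 to compound 3 exchanges acetyl for cyano, while the phenylsulfonyl group stays in place in all three measured compounds. Among the compounds with values here, there is thus no measured step that bears directly on the exchange of phenylsulfonyl for benzoyl, and the data give no basis for a direction. The estimated step is a 1.2-fold lower number from compound 3 to compound 4 (0.07 log units; within the scatter), expected to stay within the scatter, with a wide margin of uncertainty in either direction. Compound 4 is therefore expected to give about 4000 nM in this assay, with an estimated range from 900 nM to 18000 nM.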

Compound 4, concentration for 50% growth inhibition: 16000 nM
Compound 4: middle estimate off by 4.0-fold (0.60 log units), on the low side, and the stated range covers the measured number.
By their numbers in this assay, from the lowest: compounds 1 and 2 (each within the scatter of the next); then compound 3; then compound 4.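

In this assay, within the data shown here, the exchange of phenylsulfonyl for benzoyl, on a double-bonded chain carbon bound to a double-bonded chain carbon and a triple-bonded carbon, gives a 3.4-fold higher number from compound 3 to compound 4 (0.53 log units; beyond the scatter) and so is a modest step beyond the scatter, showing for the first time that the group at this place affects inhibition of growth, with the phenylsulfonyl form the stronger of this pair. Both groups carry one six-membered aromatic ring of carbon only, so the step is read with such a ring present on either side, while the sulfonyl sulfur gives way to a carbonyl. No measurement is at hand that would account for this step.

Going by these compounds, whether the exchange would have a similar size with acetyl in place of the nitrile, or with methoxy on the aromatic ring as in compound 1, remains open. Also open, on these data alone, is how an ester, a carboxamide or a longer chain would compare with benzoyl and phenylsulfonyl at this same place.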